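The source may report more compounds than this note shows. Statements on the series, on what has been measured and on what is new or still open speak of the compounds shown alone.

In an ADME assay on the whole organism (Mus musculus, strain CD-1) for pharmacokinetics, at a dose of 10 mg/kg by the oral route (a higher number here means that a larger share of the oral dose reaches the circulation, a lower number that a smaller share of the oral dose reaches the circulation), compound 1 (`COc1cc([C@](O)(CCN(C)C)[C@@H](c2cc3cc(C#N)ccc3nc2OC)c2cccc(OC)c2F)cc(SC)n1`) gives 28%, compound 2 (`COc1cccc([C@H](c2cc3cc(C#N)ccc3nc2OC)[C@@](O)(CCN(C)C)c2cc(SC)nc(SC)c2)c1F`) gives 28% and compound 3 (`CCSc1cc([C@](O)(CCN(C)C)[C@@H](c2cc3cc(Br)ccc3nc2OC)c2cccc(OC)c2F)cc(SCC)n1`) gives 25%, all within the scatter of one another. Compound 4 (`CCSc1cc([C@](O)(CCN(C)C)[C@@H](c2cc3cc(C#N)ccc3nc2OC)c2cccc(OC)c2F)cc(SCC)n1`) differs from compound 3 in one place: cyano in place of bromo on an aromatic carbon. Among the measured compounds shown here, the only measured step, no change at the digits printed from compound 1 to compound 2 (within the scatter), concerns a different exchange, so no measured step tests cyano in place of bromo directly. Compound 1 carries cyano and gives 28%, which offers no sign of a shift, so no change beyond the scatter is expected in this assay. The expected step, a number 2 percentage points higher from compound 3 to compound 4 (within the scatter), is small. For compound 4 the estimate is 27%, with an expected range of 16% to 38%.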

Compound 4, oral bioavailability: 24%
For compound 4 the middle estimate is 3 percentage points above the measured one; the range from low to high includes it.
By their numbers in this assay, from the lowest: compounds 4, 3, 1 and 2 (each within the scatter of the next).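

Cyano in place of bromo on this aromatic carbon now has a direct test in this assay, which gives a number 1 percentage points lower from compound 3 to compound 4 (within the scatter) and so shows bromo and cyano as interchangeable here at this resolution. With cyano held constant, the group of 12 heavy atoms in place of either group of 10 gives a number 4 percentage points lower from compound 2 to compound 4 (within the scatter) and a number 4 percentage points lower from compound 1 to compound 4 (within the scatter) and so also stays within the scatter. Nothing available explains these results.

From the compounds shown here alone, whether an amine or a carboxylic acid on this aromatic carbon would give a step beyond the scatter remains open. A propylsulfanyl group in place of the ethylsulfanyl groups also remains untested among the compounds shown.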